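The source may hold more compounds than are shown below. What is called first, only, known or untested is meant among the compounds shown, and "the series" means these compounds.

Compound 1 `CCCNc1nc(N)nc2ccccc12`: > 25000 nM
Compound 2 `CCCCNc1nc(N)nc2cccc(CCc3ccccc3)c12`: > 25000 nM

In an ADME assay on HEK293 cells (Homo sapiens) for cytotoxicity, with a stated time of 6 h (a higher number here means that more compound is tolerated, a lower number that less compound is tolerated), compound 1 gives > 25000 nM, which is a limit and not a number. In the same assay compound 2 gives > 25000 nM, again a limit. Compound 2 therefore has no exact value, and its place is defined only by the limit of > 25000 nM in this assay, at which 2 of the 2 values shown sit.

Compound 3 `CCCCNc1nc(N)nc2cccc(C(=O)NC)c12` is built from compound 2 by one change, methylcarbamoyl in place of phenethyl on an aromatic carbon. The new group sits ortho to a fused ring and meta to a fused ring.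

Going by the values given here, no measured pair of compounds differing in one place is available, so the size of this change in this assay cannot be read directly from the data. The expectation rests on compound 2 with its limit of > 25000 nM, and no change beyond the scatter is expected. The estimated step that the limit leaves unreadable from compound 2 to compound 3 is correspondingly small. The assay will most likely report only a limit again. If a number does appear, the estimate for compound 3 is 30000 nM, with an expected range from 15000 nM to 50000 nM.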

Compound 3, half-maximal cytotoxic concentration: > 25000 nM
Compound 3 gave a limit, no number; the forecaster's own chance of this, stated with the estimate: 85%; the middle value does not contradict the limit.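

In this assay compound 3 gives > 25000 nM, which is a limit and not a number. Compound 2 also has only a limit, and no size can be read for the step between compound 2 and compound 3. The compounds shown leave open what exact concentration of any of them is tolerated, since all share one reading: the limit of > 25000 nM in this assay, at which 3 of the 3 values shown sit.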